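A few compounds are considered here, and "the series" means these few. Any claim that something is new, unique, unknown or untested is made for them only; others in the source may bear on it.

In a functional assay on NCI-H460 cells (Homo sapiens) for antiproliferative activity, read by MTT assay, with a stated time of 72 h (on this read-out lower numbers stand for stronger inhibition and higher numbers for weaker inhibition), compound 1 `O=C(Nc1ccc(Oc2ccnc3[nH]ccc23)cc1)c1cc2cccnc2n(-c2ccc(Cl)cc2)c1=O` gives 290 nM. Compound 2 `O=C(Nc1ccc(Oc2ccnc3[nH]ccc23)cc1)c1cc2cccnc2n(-c2ccc(Br)cc2)c1=O` differs from compound 1 only in the ring attached to the aromatic nitrogen, and in this assay compound 2 gives "not determined" (no result reported), so it cannot be placed against compound 1. Compound 3 `O=C(Nc1ccc(Oc2ccnc3[nH]ccc23)cc1)c1cc2cccnc2n(-c2ccc(C(F)(F)F)cc2Cl)c1=O` carries 2-chloro-4-(trifluoromethyl)phenyl in place of 4-bromophenyl on an aromatic nitrogen. For the measured compounds named here, with no measured step between neighbours of this kind, a shift of modest size in either direction, or none beyond the usual scatter, is expected. In this assay compound 3 is therefore estimated at 400 nM, with a range from 100 nM to 1600 nM.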

Compound 3, half-maximal inhibitory concentration: 1950 nM
Estimate against measurement, compound 3: 4.9-fold (0.69 log units) below; measured number outside the range, above it.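

In this assay, the ring on the aromatic nitrogen proves sensitive to substitution: 2-chloro-4-(trifluoromethyl)phenyl in place of 4-chlorophenyl gives a 6.7-fold higher number from compound 1 to compound 3 (0.83 log units; beyond the scatter) and therefore weaker inhibition. Nothing available explains this loss. For the compounds shown here, the new ring differs from 4-chlorophenyl in more than one feature, so the single step cannot show which feature matters.

The compounds shown leave open how this ring would respond to a single added chlorine or to trifluoromethyl alone. They also leave open how it would respond to a methoxy group or an amine.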